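The compounds below may be only part of what the source reports. "The series", "measured", "known", "first", "only" and "open" are said of these compounds alone.

Compound 1 `Nc1cc(N)c2nc(-c3ccccc3)c(NCc3ccc(Cl)c(Cl)c3)nc2c1` gives < 100000 nM in a functional assay on RXF 393 cells (Homo sapiens) for inhibition, read by sulforhodamine B assay, with a stated time of 48 h (on this read-out lower numbers stand for higher toxicity in this test and higher numbers for lower toxicity in this test), and this value is a limit of the assay rather than a number.
Compound 2 `Nc1cc(N)c2nc(-c3ccccc3)c(Sc3ccc(F)cc3)nc2c1` gives < 100000 nM in this assay, again a limit.
Compound 3 `COc1cc(CNc2nc3cc(N)cc(N)c3nc2-c2ccccc2)cc(OC)c1OC` gives < 50200 nM in this assay, likewise a limit.

Compound 2 therefore stands where the numbers shown do not separate anything: all three results are limits, two of them at the limit of < 100000 nM in this assay, at which 2 of the 3 values shown sit, and one at the limit of < 50200 nM in this assay, at which 1 of the 3 values shown sits, so no compound can be called more or less toxic than another on this evidence. Among the compounds with values here, no pair of measured compounds differs in one place, so no measured step is available.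

Compound 4 `Nc1cc(N)c2nc(-c3ccccc3)c(Sc3ccc(Cl)c(Cl)c3)nc2c1` is unmeasured. It differs from compound 2 in one place: 3,4-dichlorophenyl in place of 4-fluorophenyl on a sulfur. Within the data shown here, the measured compounds offer no step that would show what such a change does in this assay. The expectation for compound 4 is therefore a step from compound 2 of about a step that the limit leaves unreadable from compound 2 to compound 4, which is no more than none beyond the usual scatter, and the result is expected to be reported, as for compound 2, only as a limit. On that basis compound 4 is estimated at 30000 nM, with a range from 5000 nM to 100000 nM.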

Compound 4, concentration lethal to 50% of the cells: 60300 nM
Estimate against measurement, compound 4: 2.0-fold (0.30 log units) below; the measured number falls inside the stated range.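

In this assay compound 2 gives < 100000 nM, which is a limit, so the change to compound 4, 3,4-dichlorophenyl in place of 4-fluorophenyl on a sulfur, cannot be read as a step. The compounds shown leave open whether this exchange of groups alters the result at all, and in which direction.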